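The compounds below may be only part of what the source reports. "The series", "measured", "known", "first", "only" and "open" are said of these compounds alone.

Working notes on the series.

Three compounds have been run in an assay on isolated protein for inhibition of high affinity nerve growth factor receptor (Homo sapiens), read by HTRF, tested at 10 uM; a higher number here means more inhibition at the concentration tested (going by the name of the read-out), a lower number less inhibition. Compound 1 `Cc1cccc(Oc2ccnc(N3CCN(C(=O)c4c(C)noc4C)CC3)n2)c1` gives 8%. Compound 2 `Clc1ccc2sc(CN3CCN(c4ncnc5c4CN(Cc4ccccc4)CC5)CC3)cc2c1` gives 13%, and compound 3 `O=C(CN1CCN(c2ncnc3c2CN(Cc2ccccc2)CC3)CC1)Nc1cc(F)ccc1F` gives 10%. On these numbers compound 2 holds the highest value of the three, though the gap to compound 3 is a number 3 percentage points lower from compound 2 to compound 3 (within the scatter) and the gap to compound 1 is likewise inside the scatter, so no ordering among the three can be read from them.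

Going by the values given here, the single measured step is a number 3 percentage points lower from compound 2 to compound 3 (within the scatter), a swap of (2,5-difluorophenyl)carbamoyl for 5-chloro-1-benzothiophen-2-yl on a saturated chain carbon bound to an amine nitrogen in a ring, and it left the read-out flat.

Compound 4 `Cc1cc(C(=O)N2CCN(c3ncnc4c3CN(Cc3ccccc3)CC4)CC2)c(C)n1C` differs from compound 2 in this way: (1,2,5-trimethyl-1H-pyrrol-3-yl)carbonyl in place of (5-chloro-1-benzothiophen-2-yl)methyl on an amine nitrogen in a ring. The change sits on the same ring nitrogen that the measured step touched, and that step, the only one that bears on it, was inside the scatter. All three measured values cluster at a low level. The expectation for compound 4 is therefore a step of a number 3 percentage points lower from compound 2 to compound 4 (within the scatter), not beyond the scatter. Compound 4 is estimated at 10%, with a range from 0% to 25%.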

Compound 4, a percentage reported as inhibition, at one concentration (the size of the read-out at that concentration, not a potency): 0%
For compound 4 the middle estimate is 10 percentage points above the measured one; the range from low to high includes it.
By their numbers in this assay, from the lowest: compounds 4, 1, 3 and 2 (each within the scatter of the next, the first and the last beyond it).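

In this assay, the amine nitrogen in the six-membered non-aromatic ring with 2 nitrogen is now the first position in the series where a change moves the read-out beyond the scatter, with a number 13 percentage points lower from compound 2 to compound 4 (beyond the scatter). The position is therefore not indifferent to what it carries: the other step there, a number 3 percentage points lower from compound 2 to compound 3 (within the scatter), kept a saturated chain carbon on that nitrogen and stayed within the scatter, whereas this change puts a carbonyl on the nitrogen and removes the six-membered aromatic ring of carbon only. Nothing at hand explains the lower number, and this single step cannot separate the carbonyl link from the change of ring system.

Still open, going by these compounds, is which of those two parts of the change carries the step, a question that (1,2,5-trimethyl-1H-pyrrol-3-yl)methyl or (5-chloro-1-benzothiophen-2-yl)carbonyl on the same nitrogen would address. Also open, on these data alone, is whether any group at this position lifts the read-out clear of the low level seen so far, for example a longer chain ending in a 5-chlorobenzothiophene or a carboxylic acid.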